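This account rests on a few compounds, and the source may have more. Where it says the series, first, only, none or still open, it means among the compounds named here.

Measured so far:

Compound 1 `Cc1ccc(COc2nc3ccccc3s2)cc1` — in a functional assay on the whole organism with Mus musculus as the target, in the writhing test, at a dose of 100 mg/kg by the intraperitoneal route (a higher number here means more inhibition at the dose given (going by the name of the read-out), a lower number less inhibition), compound 1 is reported as "not active" (no number reported).
Compound 2 `COc1cc(COc2nc3ccccc3s2)cc(OC)c1` — in this assay compound 2 gives 51.9%.

Compound 1 stands with no single number: its result is given as a reported verdict, reported as not active, rather than as a percentage, so it cannot be placed on the same scale as compound 2, which carries two methoxy groups on the benzylic ring and reaches roughly half inhibition. The two compounds differ in more than one place, so nothing further can be drawn from that pair.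

Compound 3 `Clc1ccc(COc2nc3ccccc3s2)cc1` differs from compound 1 in a single spot: chloro in place of methyl on an aromatic carbon. Among the compounds with values here, no measured pair shows this exchange, so the expectation for the step in this assay rests on thin ground. Given that compound 1 is reported as "not active" (no number reported), a small upward move at most is expected, quite possibly none beyond the usual scatter, and a verdict of not active again would not surprise. For compound 3 the inhibition in this assay is estimated at about 20%, with a plausible range from 0% to 45%.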

Compound 3, a percentage reported as inhibition, in the whole organism at one dose (the size of the read-out at that dose, not a potency): 51.9%
Compound 3: the middle estimate sits 31.9 percentage points below what was measured; the measured number lies above the stated range.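

No step can be read from compound 1 to compound 3: compound 1 carries only a verdict, with no number, and compound 3 gives 51.9% as a percentage. Nothing shown here offers an explanation for this result. In this assay the compounds shown leave open how large the change from methyl to chloro truly is.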